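Swapping methyl for fluoro on the double-bonded carbon

The source may report more compounds than this note shows. Statements on the series, on what has been measured and on what is new or still open speak of the compounds shown alone.

Measured so far in an ADME assay for pharmacokinetics, read by LC-MS, in phosphate buffer, with a stated time of 120 min, at pH 7.4, tested at 1 uM, in the presence of a further agent that is not named here; a lower number here means that the compound disappears faster, a higher number that the compound lasts longer

Compound 1 (`C=C(C(=O)Nc1ccccc1)C(F)(F)F`) gives 0.25 h
Compound 2 (`O=C(/C=C/CF)Nc1ccccc1`) gives > 8.53 h as a limit
Compound 3 (`C=C(C)C(=O)Nc1ccccc1`) gives > 8.53 h as a limit

Compound 3 stands at the limit of > 8.53 h in this assay, at which 2 of the 3 values shown sit, and so has no exact number. Compound 4 (`C=C(F)C(=O)Nc1ccccc1`) has fluoro in place of methyl on a double-bonded chain carbon bound to a carbonyl carbon. The step that bears most closely is an at least 34-fold higher number from compound 1 to compound 3 (1.53 log units; beyond the scatter) at this same place. The step that the two limits leave unreadable from compound 2 to compound 3 gives no guidance. Compound 1 gives 0.25 h with trifluoromethyl there, and fluoro is a different group, so a smaller drop from compound 3 is expected. The expected change is an at least 2.1-fold lower number from compound 3 to compound 4 (0.32 log units; beyond the scatter) in this assay and it points to a shorter half-life. For compound 4 the estimate is 4 h with an expected range of 1 h to 12 h in this measurement.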

Compound 4, half-life: > 8.53 h
Compound 4 ended at the assay's limit; the forecaster's own chance of this, stated with the estimate: 35%; middle value at least 2.1-fold (0.32 log units) away from the limit.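

On the double-bonded chain carbon bound to a carbonyl carbon, a single fluoro does not bring the short half-life seen with trifluoromethyl in this assay, with an at least 34-fold higher number from compound 1 to compound 4 (1.53 log units; beyond the scatter). Fluoro and trifluoromethyl therefore cannot be treated as alike at this place, and among compounds 1, 3 and 4, only trifluoromethyl gives an exact number. The steps from compound 3 to compound 4 and from compound 2 to compound 4 cannot be read, because both ends of each stand at one limit: the limit of > 8.53 h in this assay, at which 3 of the 4 values shown sit.

Going by these compounds, whether fluoro and methyl differ here remains open. So does how chloro or a nitrile at this place would behave.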